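The compounds below may be only part of what the source reports. "The series", "measured", "known", "first", "only" and "open" are said of these compounds alone.

Compound 2 `Cc1ccc(S(=O)(=O)N[C@H]2CC[C@@H](F)[C@@H]2CCCCOCC(=O)O)cc1` gives 1800 nM in a functional assay on a cell-free system (plasma) for inhibition of thromboxane A2 receptor (Homo sapiens), read by turbidimetry (on this read-out lower numbers stand for stronger inhibition and higher numbers for weaker inhibition), and it stands level with compound 1 `O=C(O)COCCCC[C@H]1[C@H](F)CC[C@@H]1NS(=O)(=O)c1ccc(F)cc1F`, which gives 1800 nM in this assay. For the measured compounds named here, the one measured step between them, no change at the digits printed from compound 1 to compound 2 (within the scatter), exchanged the whole aromatic group on the sulfonyl sulfur without moving the number beyond the scatter. Compound 3 `O=C(O)COCCCC[C@H]1[C@H](F)CC[C@@H]1NS(=O)(=O)c1ccccc1` differs from compound 2 by hydrogen in place of methyl on an aromatic carbon, the group sitting on an aromatic carbon of the six-membered carbon-only ring, para to a large group; cut one bond further out this reads as 4-methylphenyl to phenyl. Going by the values given here, only the step from compound 1 to compound 2 bears on this change, and it was flat, so a smaller trimming of the same ring is expected to leave this assay unchanged beyond the scatter, with no change at the digits printed from compound 2 to compound 3 (within the scatter) as the expected step. Compound 3 is therefore estimated at 1800 nM in this assay, within 800 nM to 4000 nM.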

Compound 3, half-maximal inhibitory concentration: 1700 nM
Beside the measured number, compound 3's estimate is 1.1-fold (0.02 log units) above it, within the range that was stated.
By their numbers in this assay, from the lowest: compounds 3, 1 and 2 (each within the scatter of the next).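

In this assay, taking the methyl off the aromatic carbon para to a large group gives a 1.1-fold lower number from compound 2 to compound 3 (0.02 log units; within the scatter), and the phenyl in place of 2,4-difluorophenyl gives a 1.1-fold lower number from compound 1 to compound 3 (0.02 log units; within the scatter). The unsubstituted phenyl thus stands level with both substituted rings, so across these three compounds neither the methyl nor the two fluorines move the number beyond the scatter, and the earlier step alone could not show this, since it exchanged one substituted ring for another. Nothing available explains why this position is so flat.

On these data alone, all three compounds carry only hydrogen, methyl or fluorine on this ring, so whether a methoxy group, a nitrile or a larger group such as a second phenyl ring would shift the number remains open. Equally open, as far as these compounds go, is how the number responds to changes elsewhere, such as an amide in place of the carboxylic acid.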